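Methyl in Place of Cyano on an Azo Urea

The source may hold more compounds than are shown below. What is called first, only, known or untested is meant among the compounds shown, and "the series" means these compounds.

Measured compounds:
compound 1 `CN(/N=N/c1ccc(C#N)cc1)C(=O)CCc1ccc(O)cc1` — "not determined" (no result reported) in a physicochemical assay for lipophilicity, read by HPLC, in phosphate buffer, measured as octanol-water partition, with a stated time of 30 min; on this read-out lower numbers stand for lower lipophilicity and higher numbers for higher lipophilicity
compound 2 `CN(/N=N/c1ccc(C#N)cc1)C(=O)NCCSc1ccc(O)cc1` — 3.49 in this assay

Two compounds share a phenol tail joined through a chain to an azo-bearing aromatic ring. Compound 1 `CN(/N=N/c1ccc(C#N)cc1)C(=O)CCc1ccc(O)cc1` was entered into this assay, but its entry reads "not determined" (no result reported), so no number is available for it. For the measured compounds named here, compound 2 `CN(/N=N/c1ccc(C#N)cc1)C(=O)NCCSc1ccc(O)cc1` gives 3.49 in this assay, and that is the only number available, so there is no step between measured compounds to weigh against the usual scatter.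

Compound 3 `Cc1ccc(/N=N/N(C)C(=O)NCCSc2ccc(O)cc2)cc1` is the next candidate. It differs from compound 2 in one place: methyl in place of cyano on an aromatic carbon. Going by the values given here, no measured pair shows what such a swap does here, so any expectation rests on the change itself rather than on a recorded step.

The step of a number 0.91 log units higher from compound 2 to compound 3 (beyond the scatter) is expected to lie beyond the scatter, in the direction of higher lipophilicity. For compound 3 the estimate in this assay is 4.4, with a range from 3.9 to 4.9, to be checked once the measurement is in hand.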

Compound 3, partition coefficient: 4.21
Beside the measured number, compound 3's estimate is 0.19 log units above it, and the stated range covers the measured number.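

For the compounds shown here, replacing cyano with methyl gives the first measurable step in this small set: in this assay, the swap produces a number 0.72 log units higher from compound 2 to compound 3 (beyond the scatter). This shows that the read-out responds to what sits on this aromatic carbon, para to a large group, even though the change is small: cyano leaves with 2 heavy atoms and 1 hydrogen-bond acceptor, while methyl enters with 1 heavy atom and no acceptor, and neither a ring nor a net charge is involved. No separate measurement here accounts for the size or direction of this step.

This is one pair at one position, so it does not show how the number would respond to an amine or a carboxylic acid on the same aromatic carbon, or whether those groups would fall on the same side of compound 2. It also leaves open whether the same swap from 4-cyanophenyl to 4-methylphenyl would give a similar step if a longer chain carried the phenol tail.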